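Removing the substituted aryl group from compound 3

The source may hold more compounds than are shown below. What is called first, only, known or untested is meant among the compounds shown, and "the series" means these compounds.

- compound 1 `CN(C)C(=O)c1cc2cnc(Nc3ccc(NC(=O)C4(C(=O)Nc5cccc(O)c5)CC4)cc3)nc2n1C1CCCC1` gives 58.5%
- compound 2 `CN(C)C(=O)c1cc2cnc(Nc3ccc(NC(=O)C4(C(=O)Nc5cccc(Cl)c5)CC4)cc3)nc2n1C1CCCC1` gives 15.5%
- compound 3 `CN(C)C(=O)c1cc2cnc(Nc3ccc(NC(=O)C4(C(=O)Nc5ccc(Cl)c(C(F)(F)F)c5)CC4)cc3)nc2n1C1CCCC1` gives -2.4%

In a functional assay on OVCAR-5 cells (Homo sapiens) for inhibition, read by CCK-8 assay, with a stated time of 72 h, tested at 1 uM (a lower number here means less inhibition of growth, a higher number more inhibition of growth at the concentration tested), compound 3 has the lowest number of the three, and both other compounds stand above it beyond the scatter. Compound 4 `CN(C)C(=O)c1cc2cnc(Nc3ccc(NC(=O)C4(C(=O)Nc5ccccc5)CC4)cc3)nc2n1C1CCCC1` differs from it in one place: phenyl in place of 4-chloro-3-(trifluoromethyl)phenyl on an amide-type nitrogen. This puts phenyl in place of 4-chloro-3-(trifluoromethyl)phenyl on an amide-type nitrogen.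

Within the data shown here, two measured steps bear on this change. The modest one is a number 17.9 percentage points lower from compound 2 to compound 3 (beyond the scatter), and the large one is a number 60.9 percentage points lower from compound 1 to compound 3 (beyond the scatter). Among the measured compounds shown here, no compound with plain phenyl has been measured, so the size remains uncertain. A modest to large rise in this assay is therefore expected. The expected change is a number 27.4 percentage points higher from compound 3 to compound 4 (beyond the scatter). For compound 4 the estimated value is 25%, within an expected range of 5% to 50%.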

Compound 4, percent growth inhibition at one concentration: 52.1%
Compound 4: the middle estimate sits 27.1 percentage points below what was measured; measured number outside the range, above it.
By their numbers in this assay, from the lowest: compound 3; then compound 2; then compounds 4 and 1 (each within the scatter of the next).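

Plain phenyl on the amide-type nitrogen does not fall with the halogen-bearing rings in this assay: the step is a number 54.5 percentage points higher from compound 3 to compound 4 (beyond the scatter), and removing the single chloro already gives a number 36.6 percentage points higher from compound 2 to compound 4 (beyond the scatter). The hydroxy group therefore turns out not to be needed for this level of growth inhibition, since replacing it with hydrogen gives a number 6.4 percentage points lower from compound 1 to compound 4 (within the scatter). What the low readings reflect is a loss tied to chloro and the 4-chloro-3-(trifluoromethyl)phenyl group, not a gain from hydroxy. Nothing available explains this difference. Going by these compounds, whether an amino or methoxy group on this ring would read like hydrogen or like chloro remains open.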